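Swapping the Isopropyl Group Around the Aromatic Ring

This account rests on a few compounds, and the source may have more. Where it says the series, first, only, none or still open, it means among the compounds named here.

Two compounds share a sugar-like core that carries an aryl group on an oxygen on a saturated carbon. Compound 1 `CO[C@@H]1O[C@H](COc2ccc(-c3ccccc3)cc2)[C@@H](O)[C@H](O)[C@H]1Oc1ccc(OC2CCCCC2)cc1` carries 4-phenylphenyl there, and in a functional assay on MDA-MB-231 cells (Homo sapiens) for cytotoxicity, read by MTT assay, with a stated time of 48 h (a lower number here means that less compound is needed, a higher number that more compound is needed for the effect), compound 1 gives 36000 nM. Compound 2 `CO[C@@H]1O[C@H](COc2cccc(C(C)C)c2)[C@@H](O)[C@H](O)[C@H]1Oc1ccc(OC2CCCCC2)cc1` carries 3-isopropylphenyl instead, and in this assay compound 2 gives 40000 nM. For the measured compounds named here, the single measured step, a 1.1-fold higher number from compound 1 to compound 2 (0.05 log units; within the scatter), shows that exchanging the whole aryl group left the number essentially where it was. Compound 2 thus holds the higher of the two numbers, but it sits so close to compound 1 that the two cannot be told apart.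

Compound 3 `CO[C@@H]1O[C@H](COc2ccccc2C(C)C)[C@@H](O)[C@H](O)[C@H]1Oc1ccc(OC2CCCCC2)cc1` differs from compound 2 in one place: 2-isopropylphenyl in place of 3-isopropylphenyl on an oxygen on a saturated carbon. The two compounds have the same atoms, joined differently. Because the step of a 1.1-fold higher number from compound 1 to compound 2 (0.05 log units; within the scatter) replaced the entire aryl group without moving the number beyond the scatter, this smaller swap is expected to leave the number within scatter as well, giving an expected step of no change at the digits printed from compound 2 to compound 3 (within the scatter). Compound 3 is therefore estimated at 40000 nM, with a likely range from 15000 nM to 100000 nM.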

Compound 3, half-maximal effective concentration: 44000 nM
Compound 3: middle estimate off by 1.1-fold (0.04 log units), on the low side; measured number inside the range.
By their numbers in this assay, from the lowest: compounds 1, 2 and 3 (each within the scatter of the next).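

In this assay, for the compounds shown here, the earlier compounds showed only that one whole aryl group could stand in for another on an oxygen on a saturated carbon. The new result adds that where the isopropyl group sits on the ring makes no readable difference either, with a 1.1-fold higher number from compound 2 to compound 3 (0.04 log units; within the scatter) as the step for 2-isopropylphenyl in place of 3-isopropylphenyl, and the comparison with the 4-phenylphenyl compound agrees, with a 1.2-fold higher number from compound 1 to compound 3 (0.09 log units; within the scatter) as its step, so that all three aryl groups give numbers that cannot be told apart. Nothing measured here offers an explanation for why these numbers sit so close together.

The compounds shown leave open whether a group of a different kind at this place, such as an amine or a carboxylic acid carried on the aromatic ring, would move the number beyond the scatter. They also leave open how much the rest of the molecule matters, since every change here falls at this one place and the remainder of the shared core stays the same in all three compounds.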